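Swapping the Five-Membered Aryl for Pyridin-4-yl

The compounds below may be only part of what the source reports. "The series", "measured", "known", "first", "only" and "open" are said of these compounds alone.

Compound 1: `CC(=O)N1CCCC([C@@H]2[C@@H](C(=O)Nc3ccc(F)c(C#N)c3)c3ccccc3C(=O)N2CC(C)C)C1`, 69000 nM
Compound 2: `CC(C)CN1C(=O)c2ccccc2[C@H](C(=O)Nc2ccc(F)c(C#N)c2)[C@H]1c1ccoc1`, 15000 nM
Compound 3: `CC(C)CN1C(=O)c2ccccc2[C@H](C(=O)Nc2ccc(F)c(C#N)c2)[C@H]1c1ccc(C#N)s1`, 4900 nM

In a physicochemical assay for solubility, in phosphate buffer, with a stated time of 18 h, at pH 7 (on this read-out lower numbers stand for lower solubility and higher numbers for higher solubility), compound 2 stands second highest of the three numbers; its nearest neighbour is compound 3, reached by a 3.1-fold lower number from compound 2 to compound 3 (0.49 log units; beyond the scatter), and its furthest is compound 1, from which compound 2 is separated by a 4.6-fold lower number from compound 1 to compound 2 (0.66 log units; beyond the scatter). Compound 4 is `CC(C)CN1C(=O)c2ccccc2[C@H](C(=O)Nc2ccc(F)c(C#N)c2)[C@H]1c1ccncc1`; its change from compound 2 is pyridin-4-yl in place of furan-3-yl on a saturated ring carbon. Both earlier steps at this saturated ring carbon moved this assay well beyond the scatter, so the new swap is also likely to register. Compound 4 is expected to lie between compound 2 and compound 1, with a 2.0-fold higher number from compound 2 to compound 4 (0.30 log units; within the scatter) as the estimated step. For compound 4 the estimate is 30000 nM, ranging from 12000 nM to 75000 nM.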

Compound 4, solubility: 55000 nM
The estimate for compound 4 lay 1.8-fold (0.26 log units) below the measured number; low and high end bracket the measured number.
By their numbers in this assay, from the lowest: compound 3; then compound 2; then compounds 4 and 1 (each within the scatter of the next).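

In this assay the change to pyridin-4-yl brings a 3.7-fold higher number from compound 2 to compound 4 (0.56 log units; beyond the scatter) and an 11-fold higher number from compound 3 to compound 4 (1.05 log units; beyond the scatter) and thus shows that an aromatic ring on this saturated ring carbon need not sit at the low end of the set. With a 1.3-fold lower number from compound 1 to compound 4 (0.10 log units; within the scatter) as the remaining step, pyridin-4-yl cannot be told apart from the non-aromatic 1-acetylpiperidin-3-yl at this position. No measurement given here accounts for these differences. Still open, on these data alone, is whether a plain phenyl ring would read like pyridin-4-yl, and where a morpholine or a carboxylic acid on this carbon would fall.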